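Isopropyl Ester in Place of the Acyloxymethyl Ester

The compounds below may be only part of what the source reports. "The series", "measured", "known", "first", "only" and "open" are said of these compounds alone.

Three measured compounds share one core and differ only in the group on the carbonyl carbon of the acyloxymethyl ester. Compound 1 `C[C@@H](O)[C@H]1C(=O)N2C(C(=O)OCOC(=O)C(C)(C)C)=C(S[C@@H]3CN[C@H](C(=O)Nc4cccc(C(=O)O)c4)C3)[C@H](C)[C@H]12` carries tert-butyl there, compound 2 `CCC(CC)C(=O)OCOC(=O)C1=C(S[C@@H]2CN[C@H](C(=O)Nc3cccc(C(=O)O)c3)C2)[C@H](C)[C@@H]2[C@@H]([C@@H](C)O)C(=O)N12` pentan-3-yl, and compound 3 `C[C@@H](O)[C@H]1C(=O)N2C(C(=O)OCOC(=O)C3CCCCC3)=C(S[C@@H]3CN[C@H](C(=O)Nc4cccc(C(=O)O)c4)C3)[C@H](C)[C@H]12` cyclohexyl. In an ADME assay for metabolic stability, read by LC-MS, with a stated time of 3 h, at pH 6.5, tested at 50 uM (a higher number here means that more of the compound is left, a lower number that less of the compound is left), compound 1 gives > 95%, which is a limit of the assay. In this assay compound 2 gives > 95%, again a limit. In this assay compound 3 gives > 95%, also a limit. The steps among them, a step that the two limits leave unreadable from compound 1 to compound 2, a step that the two limits leave unreadable from compound 1 to compound 3 and a step that the two limits leave unreadable from compound 2 to compound 3, therefore cannot be sized, because of the limit of > 95% in this assay, at which 3 of the 3 values shown sit.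

Compound 4 `CC(C)OC(=O)C1=C(S[C@@H]2CN[C@H](C(=O)Nc3cccc(C(=O)O)c3)C2)[C@H](C)[C@@H]2[C@@H]([C@@H](C)O)C(=O)N12` is the next compound to be measured. It differs from compound 3 as follows: isopropyl in place of ((cyclohexylcarbonyl)oxy)methyl on an oxygen next to a carbonyl group. The change reaches beyond what the three measured steps cover, since all of them only swapped the group on the carbonyl carbon while the ester linkage itself stayed. For the measured compounds named here, no measured step gives a direction or size for this assay here. The estimate for compound 4 in this assay is 88%, expected within 60% to 98%. The expected step of a number at least 7 percentage points lower from compound 3 to compound 4 (that floor lies within the scatter) is thus read against a limit and is uncertain.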

Compound 4, percent of the compound remaining: > 95%
Compound 4 gave a limit, no number; the forecaster's own chance of this, stated with the estimate: 45%; at least 7 percentage points between middle value and limit.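

In this assay compound 4 gives > 95%, which is a limit. The steps from compound 1, compound 2 and compound 3 to compound 4 therefore cannot be read, because all four compounds stand at the same limit: the limit of > 95% in this assay, at which 4 of the 4 values shown sit.

The compounds shown leave open whether isopropyl in place of the acyloxymethyl group changes the percentage remaining at all, and by how much.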